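The source may hold more compounds than are shown below. What is called first, only, known or untested is meant among the compounds shown, and "the series" means these compounds.

The measured compounds:
Compound 1, `CCOc1ccc(-c2cccc(C(=O)O)c2)cc1`, gives 23% in an assay on COS-7 cells for inhibition of patatin-like phospholipase domain-containing protein 2 (Mus musculus), tested at 200 uM; a higher number here means more inhibition at the concentration tested (going by the name of the read-out), a lower number less inhibition.
Compound 2, `CCOc1ccc(-c2cccc(C(=O)OCC(F)(F)F)c2)cc1`, gives 71%.
Compound 3, `CCOc1ccc(-c2cccc(C(=O)OCCOCCOC)c2)cc1`, gives 43%.

Compound 1 stands lowest of the three: compound 3 lies nearer to it, a number 20 percentage points higher from compound 1 to compound 3 (beyond the scatter), and compound 2 furthest, a number 48 percentage points higher from compound 1 to compound 2 (beyond the scatter). Compound 4, `CCOc1ccc(-c2cccc([N+](=O)[O-])c2)cc1`, differs from compound 1 by one change: nitro in place of carboxy on an aromatic carbon. Within the data shown here, no measured step makes a change of this kind. The known steps all replace the hydrogen on the oxygen next to the carbonyl group, the largest being a number 48 percentage points higher from compound 1 to compound 2 (beyond the scatter), while a number 28 percentage points lower from compound 2 to compound 3 (beyond the scatter) shows the spread between the two esters. They bear on compound 4 only indirectly, showing that each departure from the carboxy of compound 1 raised the number. A moderate upward step is therefore expected: a number 22 percentage points higher from compound 1 to compound 4 (beyond the scatter). Compound 4 is estimated at 45%, with a range from 20% to 70%.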

Compound 4, a percentage reported as inhibition, at one concentration (the size of the read-out at that concentration, not a potency): 35%
The estimate for compound 4 lay 10 percentage points above the measured number; the range from low to high includes it.
By their numbers in this assay, from the lowest: compound 1; then compounds 4 and 3 (each within the scatter of the next); then compound 2.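

On this aromatic carbon the carboxy group can be replaced outright, not only capped as an ester: in this assay nitro in place of carboxy gives a number 12 percentage points higher from compound 1 to compound 4 (beyond the scatter) and so the number rises with no carbonyl left at this place. The earlier steps shown here all kept that carbonyl, so the rise does not depend on it. Nothing available accounts for this rise.

Open, as far as these compounds go, is how a nitrile, an amide or a primary amine on this carbon would compare. The compounds shown also leave open whether nitro gives a similar step elsewhere on the ring.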